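Fluoro for Trifluoromethyl on a Nucleotide Agonist Scaffold

The source may report more compounds than this note shows. Statements on the series, on what has been measured and on what is new or still open speak of the compounds shown alone.

Compound 1 `O=P(O)(O)OP(=O)(O)OP(=O)(O)OC[C@H]1O[C@@H](c2nc3ccc(Cl)cc3s2)[C@H](O)[C@@H]1O`: 8 nM
Compound 2 `Cn1c([C@@H]2O[C@H](COP(=O)(O)OP(=O)(O)OP(=O)(O)O)[C@@H](O)[C@H]2O)nc2ccccc21`: 200 nM
Compound 3 `O=P(O)(O)OP(=O)(O)OP(=O)(O)OC[C@H]1O[C@@H](c2nc3cc(C(F)(F)F)ccc3s2)[C@H](O)[C@@H]1O`: 10 nM

In a functional assay for agonist activity at P2Y purinoceptor 2 (Homo sapiens), read by FLIPR (a lower number here means that less compound is needed, a higher number that more compound is needed for the effect), compound 3 gives the second highest of the three numbers; its value and that of compound 1 lie within the scatter of each other, while compound 2 sits far higher. Within the data shown here, the only step measured, a 25-fold higher number from compound 1 to compound 2 (1.40 log units; beyond the scatter), is large but concerns a swap of the whole aryl group on the saturated ring carbon, not a substituent on the six-membered aromatic ring. Compound 4 `O=P(O)(O)OP(=O)(O)OP(=O)(O)OC[C@H]1O[C@@H](c2nc3cc(F)ccc3s2)[C@H](O)[C@@H]1O` differs from compound 3 by fluoro in place of trifluoromethyl on an aromatic carbon. Compounds 1 and 3 show that two different substituents on this ring leave the number within the scatter, so no step beyond the scatter is expected: a 1.2-fold higher number from compound 3 to compound 4 (0.08 log units; within the scatter). Compound 4 is therefore estimated at 12 nM, between 4 nM and 40 nM.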

Compound 4, half-maximal effective concentration: 3 nM
The estimate for compound 4 lay 4.0-fold (0.60 log units) above the measured number; measured number outside the range, below it.
By their numbers in this assay, from the lowest: compound 4; then compounds 1 and 3 (each within the scatter of the next); then compound 2.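

In this assay, the substituent on this aromatic carbon proves not to be silent: with fluoro in place of trifluoromethyl, a 3.3-fold lower number from compound 3 to compound 4 (0.52 log units; beyond the scatter) is a modest step beyond the scatter. Among the aryl groups, there is a 2.7-fold lower number from compound 1 to compound 4 (0.43 log units; beyond the scatter) for a modest step and a 67-fold lower number from compound 2 to compound 4 (1.82 log units; beyond the scatter) for a large one, which places compound 4 lowest of the four. Nothing available explains these steps.

Going by these compounds, whether fluoro would match this number on the carbon bearing chloro in compound 1 stays open. So does the effect of an amine or a carboxylic acid on the carbon bearing fluoro in compound 4.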